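Smaller amide substituent on the shared core

The source may hold more compounds than are shown below. What is called first, only, known or untested is meant among the compounds shown, and "the series" means these compounds.

Compound 1 `CC(C)NC(=O)c1cc(Oc2ccc(/C=C/c3ccccn3)cc2)ccn1` — > 100000 nM
Compound 2 `CNC(=O)c1cc(Oc2ccc(/C=C/c3ccncc3)cc2)ccn1` — 18200 nM
Compound 3 `COc1ccc(CNC(=O)c2cc(Oc3ccc(/C=C/c4ccncc4)cc3)ccn2)cc1` — > 100000 nM
Compound 4 `CC(C)NC(=O)c1cc(Oc2ccc(/C=C/c3ccncc3)cc2)ccn1` — to be measured

Three compounds sharing one core were measured in a functional assay on HepG2 cells (Homo sapiens) for antiproliferative activity, read by CCK-8 assay, with a stated time of 48 h; a lower number here means a stronger inhibitor, a higher number a weaker inhibitor. Among the measured compounds shown here, compound 2 is the only one with a number, giving 18200 nM. Compound 3 reaches only a limit of the assay, > 100000 nM. For the measured compounds named here, compound 1 likewise stops at a limit, > 100000 nM; it carries the pyridine nitrogen in a different place than compound 4, so no single step connects it to the others.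

Compound 4 differs from compound 3 in one place: isopropyl in place of 4-methoxybenzyl on an amide-type nitrogen. Going by the values given here, the only measured step touching this position is an at least 5.4-fold higher number from compound 2 to compound 3 (0.73 log units; beyond the scatter), where a larger group on the amide nitrogen raised the number beyond the scatter. Removing the 4-methoxybenzyl again should reverse that, so a lower number is expected, perhaps not fully back to compound 2. Compound 4 is therefore expected to give 40000 nM, between 12000 nM and 130000 nM, a step of an at least 2.5-fold lower number from compound 3 to compound 4 (0.39 log units; beyond the scatter).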

Compound 4, half-maximal inhibitory concentration: 33700 nM
Beside the measured number, compound 4's estimate is 1.2-fold (0.07 log units) above it; the measured number falls inside the stated range.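

In this assay, isopropyl and methyl on the amide-type nitrogen cannot be told apart: a 1.9-fold higher number from compound 2 to compound 4 (0.27 log units; within the scatter). The sharp rise seen with 4-methoxybenzyl therefore does not extend to every group larger than methyl, as replacing it with isopropyl gives an at least 2.9-fold lower number from compound 3 to compound 4 (0.47 log units; beyond the scatter). With the isopropyl amide held constant, pyridin-4-yl in place of pyridin-2-yl gives an at least 2.9-fold lower number from compound 1 to compound 4 (0.47 log units; beyond the scatter), the first reading of that change, and this step and the one before it are minimum sizes only because each starts from a limit: the limit of > 100000 nM in this assay, at which 2 of the 4 values shown sit.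

The compounds shown leave open whether a plain benzyl or a longer chain such as n-butyl on the amide-type nitrogen would match methyl and isopropyl or 4-methoxybenzyl. They also leave open how pyridin-3-yl would compare with pyridin-4-yl and pyridin-2-yl.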